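Anilino series, alkoxy in place of alkyl on the aryl

A few compounds are considered here, and "the series" means these few. Any claim that something is new, unique, unknown or untested is made for them only; others in the source may bear on it.

Three compounds of one core carry different aryl groups on the amine nitrogen. Compound 1 `O=C1C(Nc2ccc(I)cc2)=CC(=O)c2c1nc1n2[C@H]2OC[C@@H](O)[C@H]2OC1` bears a 4-iodophenyl and in a functional assay on HeLa cells (Homo sapiens) for inhibition, read by sulforhodamine B assay (a lower number here means a stronger inhibitor, a higher number a weaker inhibitor), compound 1 gives 4010 nM. Compound 2 `CCCc1ccc(NC2=CC(=O)c3nc4n(c3C2=O)[C@H]2OC[C@@H](O)[C@H]2OC4)cc1` gives 4990 nM in this assay, the highest of the two numbers in hand; its nearest neighbour is compound 1, and the gap between them lies within the scatter. Compound 3 `COc1ccc(NC2=CC(=O)c3c(nc4n3[C@H]3OC[C@@H](O)[C@H]3OC4)C2=O)cc1` reaches only the assay limit of > 8000 nM in this assay, and this is a limit, not a number (the limit of > 8000 nM in this assay, at which 1 of the 3 values shown sits).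

Among the measured compounds shown here, the one measured step is an at least 1.9-fold higher number from compound 1 to compound 3 (0.29 log units; that floor lies within the scatter); its floor lies within the scatter, so the true size is unknown.

Compound 4 `CCOc1ccccc1NC1=CC(=O)c2nc3n(c2C1=O)[C@H]1OC[C@@H](O)[C@H]1OC3` is not yet measured. It differs from compound 2 by 2-ethoxyphenyl in place of 4-propylphenyl on an amine nitrogen. The step from compound 1 to compound 3 is the only one that bears on it: an alkoxy replacing a non-polar substituent pushed the value to the limit. For compound 4 a higher number than compound 2 is therefore expected, possibly at the limit again, and the estimated step is a 1.6-fold higher number from compound 2 to compound 4 (0.20 log units; within the scatter). The estimate for compound 4 is 8000 nM, with a range from 3000 nM to 20000 nM.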

Compound 4, half-maximal inhibitory concentration: 6040 nM
The estimate for compound 4 lay 1.3-fold (0.12 log units) above the measured number; low and high end bracket the measured number.
By their numbers in this assay, from the lowest: compounds 1, 2 and 4 (each within the scatter of the next). At a limit, above all of these: compound 3.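

In this assay, among the compounds shown here, this change on the amine nitrogen gives the first step that can be read as a number at both ends: a 1.2-fold higher number from compound 2 to compound 4 (0.08 log units; within the scatter). On this evidence, 2-ethoxyphenyl and 4-propylphenyl are not told apart in this assay, although the entering group carries an oxygen and a hydrogen-bond acceptor that the leaving group lacks. Compound 4 gives a measured number, so an alkoxy on the aryl does not in itself bring a value to the limit, and compound 3 stays alone at a value that is a limit and not a number: the limit of > 8000 nM in this assay, at which 1 of the 4 values shown sits.

Compound 3 and compound 4 differ both in the alkoxy chain and in where it sits on the aryl, so these compounds cannot show which of the two separates a measured number from a limit. Also open, as far as these compounds go, is whether a group of another kind on the aryl, such as an amine, a carboxylic acid or a longer alkoxy chain, would move the number beyond the scatter in this assay.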